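Trimming a hydroxylated chain on a kinase inhibitor

The source may hold more compounds than are shown below. What is called first, only, known or untested is meant among the compounds shown, and "the series" means these compounds.

Of the compounds shown here, three have been tested so far in an assay on isolated protein for inhibition of Leucine-rich repeat serine/threonine-protein kinase 2 variant G2019S (Homo sapiens), read by TR-FRET and LanthaScreen, with stated times of 50 min and 30 min, in the presence of a further agent that is not named here; on this read-out lower numbers stand for stronger inhibition and higher numbers for weaker inhibition. Compound 1 `Cc1cn(C)nc1Nc1cc2c(c(N)n1)c(C#N)c(N1CCC[C@H]1C)n2C` gives 1290 nM, compound 3 `C[C@@H]1CCCN1c1c(C#N)c2c(N)nc(Nc3ccn(C)n3)cc2n1C` gives 206 nM, and compound 2 `Cc1nn(CC(C)(C)O)cc1Nc1nc(N)c2c(C#N)c(N3CCC[C@H]3C)n(C)c2n1` gives 42 nM. Compound 2 therefore stands at the lowest number of the three, well apart from compound 3 and further still from compound 1. For the measured compounds named here, the only single-point comparison among the measured compounds is the one from compound 1 to compound 3, which shows a 6.3-fold lower number from compound 1 to compound 3 (0.80 log units; beyond the scatter) for hydrogen in place of methyl on an aromatic carbon.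

Compound 4 `Cc1nn(C)cc1Nc1nc(N)c2c(C#N)c(N3CCC[C@H]3C)n(C)c2n1` is the next candidate. Relative to compound 2 the change is hydrogen in place of 1-hydroxy-1-methylethyl on a saturated chain carbon bound to an aromatic nitrogen; cut one bond further out, the same change reads as 2-hydroxy-2-methylpropyl giving way to methyl. Going by the values given here, no measured step touches this position, since compound 1 and compound 3 differ from each other only on an aromatic carbon and share a different core from compound 2. The removal of a group carrying a hydrogen-bond donor and acceptor is expected to cost some potency, but without a direct precedent the size is uncertain. Compound 4 is expected to give about 120 nM in this assay, within a range from 40 nM to 400 nM, which corresponds to an expected step of a 2.9-fold higher number from compound 2 to compound 4 (0.46 log units; beyond the scatter).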

Compound 4, half-maximal inhibitory concentration: 30 nM
Estimate against measurement, compound 4: 4.0-fold (0.60 log units) above; the measured number lies below the stated range.
By their numbers in this assay, from the lowest: compounds 4 and 2 (each within the scatter of the next); then compound 3; then compound 1.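

Replacing 2-hydroxy-2-methylpropyl with methyl on the aromatic nitrogen gives a 1.4-fold lower number from compound 2 to compound 4 (0.15 log units; within the scatter) in this assay, so the two compounds cannot be told apart on this read-out. For the compounds shown here, this is the first direct look at this position, and it shows that the 1-hydroxy-1-methylethyl part, with its 4 heavy atoms, its hydrogen-bond donor and its hydrogen-bond acceptor, is not required to keep the number at this level on the shared core of these two compounds. No measurement at hand accounts for the two compounds reading alike, so the result describes what happens at this position without explaining it.

Going by these compounds alone, only two groups at this position can be compared here, methyl and 2-hydroxy-2-methylpropyl, so it remains open how a longer plain carbon chain, a chain ending in an amine or one ending in a carboxylic acid would read. On these data alone, it also remains open whether the same exchange would leave the number unmoved on the different core shared by compound 1 and compound 3.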